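The source may hold more compounds than are shown below. What is called first, only, known or untested is meant among the compounds shown, and "the series" means these compounds.

Compound 1 `COc1cccc(/C=N/c2c(C)n(C)n(-c3ccccc3)c2=O)c1` is the reference point of the series. In a functional assay on HT-29 cells (Homo sapiens) for cytotoxicity, read by MTT assay, with a stated time of 72 h (a lower number here means a stronger inhibitor, a higher number a weaker inhibitor), compound 1 gives 155000000 nM, the lowest of the two numbers obtained so far. Going by the values given here, compound 2 `Cc1c(/N=C/c2cccc([N+](=O)[O-])c2)c(=O)n(-c2ccccc2)n1C` gives 741000000 nM in this assay, and the step of a 4.8-fold higher number from compound 1 to compound 2 (0.68 log units; beyond the scatter) is the only measured step within the set. Compound 3 `Cc1c(/N=C/c2ccc(O)cc2)c(=O)n(-c2ccccc2)n1C` has not been run. It differs from compound 1 by 4-hydroxyphenyl in place of 3-methoxyphenyl on a carbon with a double bond to nitrogen. Among the compounds with values here, the one measured step that bears on this change is the swap of the aryl substituent in a 4.8-fold higher number from compound 1 to compound 2 (0.68 log units; beyond the scatter), which raised the number by a modest margin; the change to compound 3 also exchanges the aryl substituent, but for a different group, so the direction cannot be read off with confidence. A step near the scatter, with a slight lean upward, is expected, a 1.4-fold higher number from compound 1 to compound 3 (0.15 log units; within the scatter). For compound 3 the estimate in this assay is 220000000 nM, with a range of 70000000 nM to 700000000 nM.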

Compound 3, half-maximal inhibitory concentration: 389000000 nM
Beside the measured number, compound 3's estimate is 1.8-fold (0.25 log units) below it; the measured number falls inside the stated range.
By their numbers in this assay, from the lowest: compound 1; then compounds 3 and 2 (each within the scatter of the next).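

In this assay, the step of a 2.5-fold higher number from compound 1 to compound 3 (0.40 log units; beyond the scatter) shows that a second replacement of 3-methoxyphenyl on the carbon with a double bond to nitrogen also raises the number, so both replacements seen at this place go the same way and leave compound 1 lowest. The entering 4-hydroxyphenyl carries a hydrogen-bond donor, which 3-methoxyphenyl lacks, and the step lies beyond the scatter. Nothing available on these compounds accounts for the rise.

Compound 3 changes both the group and its ring position, and the compounds shown do not separate the two; 3-hydroxyphenyl and 4-methoxyphenyl would do so. Also open, going by these compounds, is whether any group at this place, such as an amine or a carboxylic acid on the phenyl ring, gives a number lower than that of compound 1.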